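Swapping pyridin-3-yl for 4-(methylsulfonyl)phenyl on compound 2

The source may hold more compounds than are shown below. What is called first, only, known or untested is meant among the compounds shown, and "the series" means these compounds.

In an in vitro ADME assay on microsomes from liver (Homo sapiens) for metabolic stability, read by LC-MS, using NADPH (a higher number here means that the compound lasts longer, a lower number that the compound disappears faster), compound 1 (`O=C(NCCCC(c1ccccc1)c1ccccc1)c1cccnc1`) gives 0.1 h as its half-life and compound 2 (`O=C(NCCC(c1ccc(F)cc1)c1ccc(F)cc1)c1cccnc1`) gives 0.2 h as its half-life, so compound 2 stands within the usual scatter of compound 1 and the two cannot be ranked. Compound 3 (`CS(=O)(=O)c1ccc(C(=O)NCCC(c2ccc(F)cc2)c2ccc(F)cc2)cc1`) differs from compound 2 in one place, with 4-(methylsulfonyl)phenyl in place of pyridin-3-yl on a carbonyl carbon. Going by the values given here, no measured pair shows a change at this place, so the size of the step is a judgement with little support from the data. A modest rise in this assay is expected (a 2.0-fold higher number from compound 2 to compound 3 (0.30 log units; within the scatter)) with wide uncertainty on its size. Compound 3 is estimated at 0.4 h (expected range 0.15 h to 1.2 h).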

Compound 3, half-life: 0.783 h
Beside the measured number, compound 3's estimate is 2.0-fold (0.29 log units) below it; the range from low to high includes it.
By their numbers in this assay, from the lowest: compounds 1 and 2 (each within the scatter of the next); then compound 3.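

In this assay, going by these compounds alone, the group on the carbonyl carbon proves to be a place where the half-life responds: 4-(methylsulfonyl)phenyl in place of pyridin-3-yl gives a 3.9-fold higher number from compound 2 to compound 3 (0.59 log units; beyond the scatter), the first step beyond the scatter. The change is a double one, as the ring loses its nitrogen and also gains a methylsulfonyl group, so this single step cannot separate the two. Within the data shown here, nothing measured so far accounts for the rise.

An unsubstituted phenyl on the same carbonyl carbon would show how much of the step comes from removing the ring nitrogen, and a 4-methoxyphenyl would show whether another group in that place does the same. As far as these compounds go, whether the step carries over to the core of compound 1 also remains open.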